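The compounds below may be only part of what the source reports. "The series", "measured", "known", "first", "only" and "open" are said of these compounds alone.

Among the compounds with values here, in a functional assay on U-251 cells (Homo sapiens) for inhibition, read by sulforhodamine B assay, with a stated time of 48 h (a higher number here means that more compound is tolerated, a lower number that less compound is tolerated), compound 3 `COc1cc(-c2nn(-c3cccc(NC(=O)Nc4ccc(Cl)c(C(F)(F)F)c4)c3)cc2-c2ccncc2)ccc1Cl` gives 24700 nM, the only plain number among the three values shown. Compound 1 `O=C(Nc1cccc(-n2cc(-c3ccncc3)c(-c3ccc(Cl)c(O)c3)n2)c1)Nc1cccc(C(F)(F)F)c1` returns a limit of the assay, > 32500 nM. Compound 2 `O=C(Nc1cccc(-n2cc(-c3ccncc3)c(-c3ccc(Cl)c(O)c3)n2)c1)Nc1ccc(Cl)c(Cl)c1` likewise returns a limit, > 32500 nM. The step that the two limits leave unreadable from compound 1 to compound 2 therefore cannot be sized, because both of its values sit at the limit of > 32500 nM in this assay, at which 2 of the 3 values shown sit.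

Compound 4 `O=C(Nc1cccc(-n2cc(-c3ccncc3)c(-c3ccc(Cl)c(O)c3)n2)c1)Nc1ccc(Cl)c(C(F)(F)F)c1` differs from compound 3 by hydrogen in place of methyl on an oxygen on an aromatic ring. Within the data shown here, none of the measured steps probes this change directly. What the data do offer is that compound 1 and compound 2, the two hydroxy-bearing compounds, both sit at the limit, while compound 3, which carries the methoxy group, gives a number somewhat under that limit. On that footing the expected step of a 1.4-fold higher number from compound 3 to compound 4 (0.15 log units; within the scatter) is small and points toward more compound being tolerated, with a fair chance that only a limit is reported. Compound 4 is thus estimated at 35000 nM, within a range from 15000 nM to 100000 nM.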

Compound 4, concentration lethal to 50% of the cells: 2740 nM
Compound 4: the middle estimate sits 13-fold (1.11 log units) above what was measured; measured number outside the range, below it.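

In this assay, the change from methoxy to hydroxy gives a 9.0-fold lower number from compound 3 to compound 4 (0.95 log units; beyond the scatter), which shows that this position on the 4-chloro-3-methoxyphenyl group can shift the read-out beyond the scatter. Trifluoromethyl in place of chloro on an aromatic carbon gives an at least 11-fold lower number from compound 2 to compound 4 (1.07 log units; beyond the scatter), and chloro in place of hydrogen on an aromatic carbon gives an at least 11-fold lower number from compound 1 to compound 4 (1.07 log units; beyond the scatter), so the hydroxy compounds also respond to changes on the other aryl group. The hydroxy group alone therefore does not bring the number down, since compound 1 and compound 2 also carry it, and both of these last two steps start from a limit of the assay: the limit of > 32500 nM in this assay, at which 2 of the 4 values shown sit.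

From the compounds shown here alone, it remains open whether an amine or an ethoxy group in place of the hydroxy would give a similar number. Going by these compounds, it is also open whether the step from methoxy to hydroxy would be as large with other groups on the opposite aryl ring.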